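Swapping 2-Chlorophenyl for 4-Methoxyphenyl in Compound 4

This account rests on a few compounds, and the source may have more. Where it says the series, first, only, none or still open, it means among the compounds named here.

For the measured compounds named here, in a functional assay on HCT-116 cells (Homo sapiens) for antiproliferative activity, read by MTT assay, with a stated time of 72 h (on this read-out lower numbers stand for stronger inhibition and higher numbers for weaker inhibition), compound 3 `NC1=NC2(CCSCC2)N(OCCCOc2ccccc2Cl)C(N)=N1` gives 1 nM and sits level with compound 1 `NC1=NC2(CCSCC2)N(OCCCOc2ccc(Cl)c(Cl)c2)C(N)=N1` at 1 nM and compound 2 `NC1=NC2(CCSCC2)N(OCCCOc2cc(Cl)c(Cl)cc2Cl)C(N)=N1` at 1 nM on the numbers so far. Compound 4 `COc1ccc(OCCCON2C(N)=NC(N)=NC23CCSCC3)cc1` keeps the shared core and the chain, and changes only the aromatic group, with 4-methoxyphenyl in place of 2-chlorophenyl on an oxygen on a saturated carbon. Three measured steps alter that same aromatic group, and they show no change at the digits printed from compound 1 to compound 2 (within the scatter) and no change at the digits printed from compound 1 to compound 3 (within the scatter) and no change at the digits printed from compound 2 to compound 3 (within the scatter) as well, so changing the chloro groups has left the read-out unmoved in these compounds. None of these compounds carries a methoxy group, which makes this evidence indirect. On that basis the step expected in this assay is a 1.5-fold higher number from compound 3 to compound 4 (0.18 log units; within the scatter) and no step beyond the scatter is foreseen. The estimated value for compound 4 is 1.5 nM within a range of 0.5 nM to 8 nM with more room left toward weaker inhibition.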

Compound 4, half-maximal inhibitory concentration: 70 nM
Beside the measured number, compound 4's estimate is 47-fold (1.67 log units) below it, outside the stated range (above it).
By their numbers in this assay, from the lowest: compounds 1, 2 and 3 (each within the scatter of the next); then compound 4.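

In this assay, the aromatic group on an oxygen on a saturated carbon proves far less tolerant than the chlorinated compounds suggested: the change to 4-methoxyphenyl gives a 70-fold higher number from compound 3 to compound 4 (1.85 log units; beyond the scatter), and the same large rise appears as a 70-fold higher number from compound 2 to compound 4 (1.85 log units; beyond the scatter) and as a 70-fold higher number from compound 1 to compound 4 (1.85 log units; beyond the scatter) for the other two. The level read-out therefore held only among the chlorophenyl groups shown, and compound 4, the only compound here without a chloro group, is also the only one with clearly weaker inhibition. Nothing measured here accounts for this drop.

Compound 4 both loses chloro and gains methoxy, so the compounds shown cannot separate the two changes. A plain phenyl group or a fluorophenyl group in the same place would help show which of them tracks the loss.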